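This account rests on a few compounds, and the source may have more. Where it says the series, first, only, none or still open, it means among the compounds named here.

In an assay on HEK293 cells for inhibition of sodium-dependent dopamine transporter (Homo sapiens), read by scintillation counting, with a stated time of 5 min (on this read-out higher numbers stand for weaker inhibition and lower numbers for stronger inhibition), compound 1 `CCC(=O)N(Cc1ccc2ccccc2c1)[C@@H]1CCNC1` gives 266 nM. Compound 2 `CS(=O)(=O)N(Cc1ccc2ccccc2c1)[C@@H]1CCNC1` reaches only a limit of the assay, > 68000 nM. Among the compounds with values here, the single measured step, an at least 250-fold higher number from compound 1 to compound 2 (2.40 log units; beyond the scatter), ends at the limit of > 68000 nM in this assay, at which 1 of the 2 values shown sits. Compound 3 `CS(=O)(=O)N(Cc1ccc2ccccc2c1)[C@H]1CCNC1` differs from compound 2 only in configuration: the two compounds have the same atoms and bonds and differ only in configuration as drawn: 1 of 1 stereo elements differ; a stereocentre at a saturated ring carbon is drawn R in compound 2 and S in compound 3. Within the data shown here, no measured step bears on such a change; the one step measured concerns the group on the amine nitrogen, which compounds 2 and 3 share. Compound 3 is therefore expected to stand at the same limit, with the step that the limit leaves unreadable from compound 2 to compound 3 not beyond the scatter. Compound 3 is thus estimated at 70000 nM, between 20000 nM and 200000 nM.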

Compound 3, half-maximal inhibitory concentration: 2800 nM
Estimate against measurement, compound 3: 25-fold (1.40 log units) above, outside the stated range (below it).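

With the methylsulfonyl group on the amine nitrogen, the configuration at the saturated ring carbon alone changes the read-out, giving an at least 24-fold lower number from compound 2 to compound 3 (1.38 log units; beyond the scatter) and showing that this stereocentre matters as much as a readable result. Compound 2 gives > 68000 nM which is a limit of the assay. The step can be tied to this stereocentre alone because of one fact: the fact that compounds 2 and 3 differ only in the configuration as drawn.

On these data alone, what stays open is whether the same change of configuration would move the number to a similar extent with propanoyl on that nitrogen. As far as these compounds go, how an acetyl group, a longer acyl chain or a benzoyl group would stand there also remains open.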